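This account rests on a few compounds, and the source may have more. Where it says the series, first, only, none or still open, it means among the compounds named here.

In a functional assay on the whole organism (strain Kunming) for inhibition, with Mus musculus as the target, with a stated time of 1 h, at a dose of 40 mg/kg by the oral route (on this read-out higher numbers stand for more inhibition at the one dose given (going by the name of the read-out) and lower numbers for less inhibition), compound 1 `Cc1ccc(N2CCN(c3ccc(C(=O)/C=C/c4ccccc4)cc3)CC2)c(C)c1` gives 15%. Compound 2 `O=C(/C=C/c1ccccc1)c1ccc(N2CCN(c3ccccc3)CC2)cc1` gives 3.71%. Compound 3 `Cc1ccc(S(=O)(=O)N2CCN(c3ccc(C(=O)/C=C/c4ccccc4)cc3)CC2)cc1` gives 30.8%.

Compound 3 stands highest of the three, beyond the scatter from both others: the step of a number 15.8 percentage points higher from compound 1 to compound 3 (beyond the scatter) and the step of a number 27.1 percentage points higher from compound 2 to compound 3 (beyond the scatter) both favour the (4-methylphenyl)sulfonyl group on the amine nitrogen in the ring, while a number 11.3 percentage points lower from compound 1 to compound 2 (beyond the scatter) runs downward. Compound 4 `O=C(/C=C/c1ccccc1)c1ccc(N2CCN(S(=O)(=O)c3ccc(C(F)(F)F)cc3)CC2)cc1` keeps that sulfonyl group and differs from compound 3 only at its outer ring, (trifluoromethyl in place of methyl on an aromatic carbon). For the measured compounds named here, none of the measured steps touches a group on an aromatic carbon of that ring; all three exchange the whole group on the ring nitrogen, so they bear on the change only in showing that this part of the molecule moves the read-out by modest amounts. Compound 3 is therefore taken as the anchor, and compound 4 is expected to stay near it, with a step of a number 0.8 percentage points lower from compound 3 to compound 4 (within the scatter) not beyond the scatter. Compound 4 is estimated at 30%, within 15% to 45%.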

Compound 4, a percentage reported as inhibition, in the whole organism at one dose (the size of the read-out at that dose, not a potency): 47.9%
Estimate against measurement, compound 4: 17.9 percentage points below; the whole stated range lies below it.
By their numbers in this assay, from the lowest: compound 2; then compound 1; then compound 3; then compound 4.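

The outer ring of the sulfonyl group turns out to be a sensitive place: in this assay, trifluoromethyl in place of methyl on an aromatic carbon, para to a large group, comes with a number 17.1 percentage points higher from compound 3 to compound 4 (beyond the scatter). The earlier steps shown here each exchanged the whole group on the ring nitrogen, whereas this one shows that a change confined to one substituent, 4-methylphenyl to 4-(trifluoromethyl)phenyl, is enough to move the read-out beyond the scatter. Nothing available here accounts for this step.

Going by these compounds, it remains open whether the gain is particular to trifluoromethyl or would also appear with a chlorine atom, a methoxy group or a nitrile at this place. On these data alone, it is also open whether a longer chain there would carry the read-out further or lose it.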